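The compounds below may be only part of what the source reports. "The series", "measured", "known", "first", "only" and "open" are said of these compounds alone.

In an assay on isolated protein for binding affinity to Apoptosis regulator Bcl-2 (Homo sapiens), read by isothermal titration calorimetry (on this read-out higher numbers stand for weaker binding and lower numbers for tighter binding), compound 2 `COc1ccc(Sc2ccc3c4c(cccc24)C2=NC(=O)C(C#N)=C23)cc1` gives 955 nM, the highest of the two numbers recorded so far. Compound 1 `CCCCCCNC1=C2C(=NC1=O)c1cccc3c(Sc4ccc(N)cc4)ccc2c13` gives 79.4 nM in this assay, a lower number, and the gap between the two lies beyond the usual scatter. Compound 3 `CCCCCCNC1=C2C(=NC1=O)c1cccc3c(Sc4ccc(OC)cc4)ccc2c13` has not yet been measured in this assay. It differs from compound 2 by hexylamino in place of cyano on a double-bonded ring carbon. For the measured compounds named here, no step between measured compounds covers this change alone, but compound 1 carries the same hexylamino group on its core and gives 79.4 nM in this assay, a lower number than compound 2 shows. On that basis the expected step is downward and beyond the scatter, a 9.6-fold lower number from compound 2 to compound 3 (0.98 log units; beyond the scatter). Compound 3 is therefore estimated at 100 nM in this assay, with a range from 40 nM to 300 nM.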

Compound 3, dissociation constant: 204 nM
Compound 3: the middle estimate sits 2.0-fold (0.31 log units) below what was measured, within the range that was stated.
By their numbers in this assay, from the lowest: compound 1; then compound 3; then compound 2.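

In this assay, for the compounds shown here, hexylamino in place of cyano on a double-bonded ring carbon gives a 4.7-fold lower number from compound 2 to compound 3 (0.67 log units; beyond the scatter), the first step that isolates this change with the rest of the structure held constant. The second step, a 2.6-fold higher number from compound 1 to compound 3 (0.41 log units; beyond the scatter), shows that methoxy in place of amino on an aromatic carbon also moves the number beyond the scatter, so the hexylamino group alone does not bring compound 3 to the level of compound 1. Nothing available here explains either step.

Going by these compounds, it remains open how a shorter chain such as butylamino, or a cyclic amine such as morpholine, would compare on the same ring carbon. On these data alone, it is also open whether the step between methoxy and amino keeps its size with cyano on the core, and how a carboxylic acid would read on that aromatic carbon.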